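Swapping Methyl for Chloro on the Aryl Ring

The compounds below may be only part of what the source reports. "The series", "measured", "known", "first", "only" and "open" are said of these compounds alone.

Among the measured compounds shown here, compound 2 `CC(=O)c1c(NNc2ccc(C)cc2)cc(C)oc1=O` stands at the top of the two numbers so far: in a functional assay on the whole organism for inhibition, with Rattus norvegicus as the target, read by paw edema, with a stated time of 1 h, at a dose of 50 mg/kg (a higher number here means more inhibition at the dose given (going by the name of the read-out), a lower number less inhibition), compound 2 gives 60.1%, while compound 1 `CC(=O)c1c(NNc2ccccc2)cc(C)oc1=O` gives 59.5%, and the step of a number 0.6 percentage points higher from compound 1 to compound 2 (within the scatter) stayed within the scatter. Compound 3 `CC(=O)c1c(NNc2ccc(Cl)cc2)cc(C)oc1=O` differs from compound 2 by chloro in place of methyl on an aromatic carbon. For the measured compounds named here, the only measured step altered the same aromatic carbon and moved the read-out little, so for compound 3 no shift beyond the scatter is expected in this assay, namely a number 0.1 percentage points lower from compound 2 to compound 3 (within the scatter). Compound 3 is therefore estimated at 60%, with a range from 48% to 72%.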

Compound 3, a percentage reported as inhibition, in the whole organism at one dose (the size of the read-out at that dose, not a potency): 54.4%
The estimate for compound 3 lay 5.6 percentage points above the measured number, within the range that was stated.
By their numbers in this assay, from the lowest: compounds 3, 1 and 2 (each within the scatter of the next).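

Chloro on this aromatic carbon gives a number 5.7 percentage points lower from compound 2 to compound 3 (within the scatter) and a number 5.1 percentage points lower from compound 1 to compound 3 (within the scatter) in this assay and so reads alike with both hydrogen and methyl, which extends the flat picture at this position from a carbon group to a halogen. Nothing at hand explains these numbers. Still open, as far as these compounds go, is whether an amine or a carboxylic acid on this same carbon would move the read-out beyond the scatter. From the compounds shown here alone, whether the three compounds would also read alike at another dose or time also stays open.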